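The source may report more compounds than this note shows. Statements on the series, on what has been measured and on what is new or still open speak of the compounds shown alone.

Compound 1 `Nc1cc(N)c2nc(-c3ccccc3)c(Oc3ccc(Cl)c(Cl)c3)nc2c1` gives in a functional assay on LOX IMVI cells (Homo sapiens) for inhibition, read by sulforhodamine B assay, with a stated time of 48 h (a higher number here means that more compound is tolerated, a lower number that less compound is tolerated), a value of 72400 nM. Compound 2 `COc1ccc(CNc2nc3cc(N)cc(N)c3nc2-c2ccccc2)cc1OC` shows in this assay only a limit, < 100000 nM, not a number. Compound 3 `COc1cc(CNc2nc3cc(N)cc(N)c3nc2-c2ccccc2)cc(OC)c1OC` has not yet been measured in this assay; it differs from compound 2 by methoxy in place of hydrogen on an aromatic carbon. Among the compounds with values here, no measured step shows how such a change plays out, so the step that the limit leaves unreadable from compound 2 to compound 3 is expected to stay within the usual scatter, in no particular direction. With compound 2 sitting at the limit noted in the limit of < 100000 nM in this assay, at which 1 of the 2 values shown sits, compound 3 is estimated at 70000 nM, with a range from 30000 nM to 100000 nM.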

Compound 3, concentration lethal to 50% of the cells: 26300 nM
Compound 3: middle estimate off by 2.7-fold (0.43 log units), on the high side; measured number outside the range, below it.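

No step can be read from compound 2 to compound 3, because compound 2 is known only as a limit: the limit of < 100000 nM in this assay, at which 1 of the 3 values shown sits.
In this assay, as far as these compounds go, the size and direction of the effect of methoxy in place of hydrogen remain open.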